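The source may hold more compounds than are shown below. What is called first, only, known or untested is meant among the compounds shown, and "the series" means these compounds.

Working notes on the series.

Compound 1 `CCCCOc1cccc(/C=N/n2c(-c3ccccc3)nc3ccccc3c2=O)c1` and compound 2 `CC(C)Oc1cccc(/C=N/n2c(-c3ccccc3)nc3ccccc3c2=O)c1` share one core and differ only in the chain on the oxygen on the aromatic ring. In a functional assay on the whole organism (strain albino CF-1) with Mus musculus as the target, in the maximal electroshock model, with a stated time of 0.5 h (on this read-out higher numbers stand for an effect only at larger amounts of compound and lower numbers for an effect already at smaller amounts), compound 1 gives 300 mg/kg. With isopropyl in place of butyl on that oxygen, compound 2 gives 300 mg/kg in this assay, so the step of no change at the digits printed from compound 1 to compound 2 (within the scatter) leaves the read-out where it was. For the measured compounds named here, on the numbers in hand, compound 2 therefore stands level with compound 1, and nothing so far separates the two chains.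

Compound 3 `C=CCCOc1cccc(/C=N/n2c(-c3ccccc3)nc3ccccc3c2=O)c1` is the next member and is not yet measured in this assay. It departs from compound 2 by the change (but-3-en-1-yl in place of isopropyl on an oxygen on an aromatic ring). Cut one bond further out, the same difference reads isopropoxy to (but-3-en-1-yl)oxy. Going by the values given here, the only step that bears on this change is the one from compound 1 to compound 2, which was flat, so the expectation is for no step beyond the scatter, and the estimated step for compound 3 is no change at the digits printed from compound 2 to compound 3 (within the scatter). Compound 3 is accordingly expected to come in at about 300 mg/kg in this assay, with a range from 150 mg/kg to 600 mg/kg.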

Compound 3, minimum effective dose: 300 mg/kg
For compound 3 middle estimate and measured number coincide at the digits printed; the measured number falls inside the stated range.
By their numbers in this assay, from the lowest: compounds 1, 2 and 3 (each within the scatter of the next).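

In this assay the swap to but-3-en-1-yl on the oxygen on the aromatic ring gives no change at the digits printed from compound 2 to compound 3 (within the scatter), so this position now also takes a chain with a double bond outside aromatic rings, and the read-out stays level. The closer comparison, vinyl in place of ethyl two bonds along the chain from that oxygen, gives no change at the digits printed from compound 1 to compound 3 (within the scatter), which isolates the double bond at a chain length shared with butyl, something the step between the two saturated chains could not do. Nothing measured on these compounds accounts for the read-out staying level across butyl, isopropyl and but-3-en-1-yl at this position.

On these data alone, all three chains on this oxygen are built from carbon alone and are of similar size, so it stays open whether an amine or a carboxylic acid at the chain end, a longer chain such as octyl, or a benzyl group would remain level with them. The shared core is also identical throughout, which leaves open how the read-out responds to a change anywhere other than this oxygen.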